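Series notes: 3,5-difluorophenyl in place of hexyl

A few compounds are considered here, and "the series" means these few. Any claim that something is new, unique, unknown or untested is made for them only; others in the source may bear on it.

Compound 1, `O=c1cc(Cn2cc(CCO)nn2)c2ccc(O)cc2o1`, gives in a functional assay on HeLa cells (Homo sapiens) for inhibition, read by MTT assay, with a stated time of 72 h (a higher number here means a weaker inhibitor, a lower number a stronger inhibitor), only a limit, > 100000 nM. Compound 2, `CCCCCCc1cn(Cc2cc(=O)oc3cc(O)ccc23)nn1`, gives in this assay a value of 59000 nM. Among the compounds with values here, the one measured step, an at least 1.6-fold lower number from compound 1 to compound 2 (0.22 log units; that floor lies within the scatter), is set by that limit and is therefore itself no more than a floor; it concerns the chain end and not the substituent of interest here. Within the data shown here, compound 2 thus holds the only number in the set; the other value is the limit of > 100000 nM in this assay, at which 1 of the 2 values shown sits.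

Compound 3, `O=c1cc(Cn2cc(-c3cc(F)cc(F)c3)nn2)c2ccc(O)cc2o1`, differs from compound 2 by 3,5-difluorophenyl in place of hexyl on an aromatic carbon. Among the measured compounds shown here, no measured step touches this position, and the single step available, an at least 1.6-fold lower number from compound 1 to compound 2 (0.22 log units; that floor lies within the scatter), lies within the scatter at its floor, so there is no ground to expect a change beyond the scatter in this assay for compound 3 in either direction. The number for compound 3 is therefore estimated close to that of compound 2, with a 1.2-fold lower number from compound 2 to compound 3 (0.07 log units; within the scatter), at 50000 nM within a range of 12000 nM to 100000 nM; a limit rather than a number remains a real possibility for compound 3.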

Compound 3, half-maximal inhibitory concentration: 27600 nM
The estimate for compound 3 lay 1.8-fold (0.26 log units) above the measured number, within the range that was stated.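

In this assay, the aromatic carbon of the five-membered aromatic ring with 3 nitrogen now carries a step with a number at both ends: 3,5-difluorophenyl in place of hexyl gives a 2.1-fold lower number from compound 2 to compound 3 (0.33 log units; beyond the scatter) and so shows that this position can move the read-out in a change between two groups of no net charge. Against 2-hydroxyethyl, the same group gives an at least 3.6-fold lower number from compound 1 to compound 3 (0.55 log units; beyond the scatter) and so clears the scatter, which the floor of the step from compound 1 to compound 2 did not do. That second step remains a floor, since one of its ends is a limit and not a number: the limit of > 100000 nM in this assay, at which 1 of the 3 values shown sits.

Going by these compounds, how a plain phenyl or a pyridine ring would compare at this carbon stays open, so the share of the two fluorine atoms in the step cannot be separated from that of the aromatic ring that carries them. Also open, on these data alone, is how a group with an amine or a carboxylic acid would read here, or whether a longer chain than hexyl would shift the number in either direction.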